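The compounds below may be only part of what the source reports. "The series", "measured", "known", "first", "only" and "open" are said of these compounds alone.

Measured compounds:
compound 1 `O=C1c2c[n+]([O-])c3ccccc3c2C(=O)c2c1c1ccccc1n2Cc1cn([C@H]2C[C@H](O)[C@@H](CO)O2)nn1` with 620 nM
compound 2 `CC1(C)OCC(Cn2cc(Cn3c4c(c5ccccc53)C(=O)c3c[n+]([O-])c5ccccc5c3C4=O)nn2)O1` with 230 nM
compound 3 `O=C1c2c[n+]([O-])c3ccccc3c2C(=O)c2c1c1ccccc1n2Cc1cn([C@H]2O[C@H](CO)[C@@H](O)[C@H]2O)nn1` with 1340 nM

In a functional assay on SH-SY5Y cells (Homo sapiens) for cytotoxicity, read by MTT assay, with a stated time of 72 h (a lower number here means a stronger inhibitor, a higher number a weaker inhibitor), compound 3 stands with the highest number of the three. Its nearest neighbour is compound 1, as the step of a 2.2-fold higher number from compound 1 to compound 3 (0.33 log units; beyond the scatter) shows, and the widest gap separates it from compound 2, as the step of a 5.8-fold higher number from compound 2 to compound 3 (0.77 log units; beyond the scatter) shows. Compound 4 `CC1(C)OC[C@@H](Cn2cc(Cn3c4c(c5ccccc53)C(=O)c3c[n+]([O-])c5ccccc5c3C4=O)nn2)O1` is not yet measured. It differs from compound 3 as follows: (2,2-dimethyl-1,3-dioxolan-4-yl)methyl in place of 3,4-dihydroxy-5-(hydroxymethyl)oxolan-2-yl on an aromatic nitrogen. The group that enters is the same group carried by compound 2. The measured step of a 5.8-fold higher number from compound 2 to compound 3 (0.77 log units; beyond the scatter) is thus retraced in the opposite direction, and the step of a 2.7-fold lower number from compound 1 to compound 2 (0.43 log units; beyond the scatter) points the same way. A lower number is therefore expected in this assay, of a size that matches the measured steps, estimated as a 5.8-fold lower number from compound 3 to compound 4 (0.77 log units; beyond the scatter). Compound 4 is expected to give about 230 nM, within a range from 110 nM to 500 nM.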

Compound 4, half-maximal inhibitory concentration: > 1000 nM
Compound 4 ended at the assay's limit; the forecaster's own chance of this, stated with the estimate: 2%; at least 4.3-fold (0.63 log units) between middle value and limit.
By their numbers in this assay, from the lowest: compound 2; then compound 1; then compound 3.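

In this assay compound 4 gives > 1000 nM, which is a limit of the assay and not a number. The size of the change from 3,4-dihydroxy-5-(hydroxymethyl)oxolan-2-yl in compound 3 to (2,2-dimethyl-1,3-dioxolan-4-yl)methyl in compound 4 therefore cannot be read, because of this: the limit of > 1000 nM in this assay, at which 1 of the 4 values shown sits. The entering group does not settle the number on its own, as the data hold an at least 4.3-fold higher number from compound 2 to compound 4 (0.63 log units; beyond the scatter), and that gap comes with one difference in the drawing: the fact that one of compounds 2 and 4 is drawn with a defined configuration and the other without, at the place where they differ

Against the deoxy sugar of compound 1 there is an at least 1.6-fold higher number from compound 1 to compound 4 (0.20 log units; that floor lies within the scatter), a floor within the scatter, so that comparison stays open. Also open, as far as these compounds go, is how an amine or a carboxylic acid on this aromatic nitrogen would read in this assay, and how the S configuration at the saturated ring carbon would compare.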